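A hydroxymethyl group on a compound at the limit

The source may hold more compounds than are shown below. What is called first, only, known or untested is meant among the compounds shown, and "the series" means these compounds.

In a functional assay on MCF7 cells (Homo sapiens) for cytotoxicity (on this read-out higher numbers stand for weaker inhibition and lower numbers for stronger inhibition), compound 3 (`Nc1ccc(-c2nc3ccccc3s2)cc1Cl`) gives < 1 nM as its reading, which is a limit and not a number. Compound 1 (`Nc1ccc(-c2nc3ccccc3s2)cc1I`) gives < 1 nM as its reading, also a limit. Chloro in place of iodo therefore makes a step that the two limits leave unreadable from compound 1 to compound 3 (both readings rest on (the limit of < 1 nM in this assay, at which 2 of the 3 values shown sit)). Compound 2 (`Nc1ccc(-c2nc3cc(O)ccc3s2)cc1Cl`) gives a true number, 60600 nM in this assay. Hydrogen in place of hydroxy on an aromatic carbon makes an at least 60000-fold lower number from compound 2 to compound 3 (4.78 log units; beyond the scatter) and is the only measured step of readable size.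

Compound 4 (`Nc1ccc(-c2nc3ccccc3s2)cc1CO`) carries hydroxymethyl in place of chloro on an aromatic carbon, ortho to an amino group (hydroxymethyl in place of chloro on an aromatic carbon). Neither measured step makes this exchange. The iodo to chloro step gives no size to build on, and the hydroxy step concerns a different group, so it serves only as a warning and not as a measure. A higher number, meaning weaker inhibition, is expected in this assay, and the estimated step is an at least 20-fold higher number from compound 3 to compound 4 (1.30 log units; beyond the scatter) as a moderate one. The estimate for compound 4 is 20 nM as a middle value. The expected range for compound 4 runs from 1 nM to 1000 nM as its two ends.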

Compound 4, half-maximal inhibitory concentration: 6 nM
Compound 4: middle estimate off by 3.3-fold (0.52 log units), on the high side, and the stated range covers the measured number.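

In this assay, the position ortho to an amino group now has a step of readable size: hydroxymethyl in place of chloro makes an at least 6.0-fold higher number from compound 3 to compound 4 (0.77 log units; beyond the scatter), and hydroxymethyl in place of iodo makes an at least 6.0-fold higher number from compound 1 to compound 4 (0.77 log units; beyond the scatter). Among the compounds shown here, the earlier compounds gave no such size here, as the step between iodo and chloro cannot be read and the only readable step concerned a hydroxy group on another aromatic carbon, so this is the first sign that the group at this position can change the reading, with one hydrogen-bond donor and one hydrogen-bond acceptor entering where chloro and iodo carry none. Both new steps are minimum sizes and the true steps may be larger, because each starts from a reading that is a limit: the limit of < 1 nM in this assay, at which 2 of the 4 values shown sit.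

The compounds shown leave open which part of the hydroxymethyl group goes with the higher number, a question on which a methyl or a methoxymethyl group at this position would bear. They also leave open how a longer chain such as hydroxyethyl, or an aminomethyl group, would read here.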